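The source may report more compounds than this note shows. Statements on the series, on what has been measured and on what is new or still open speak of the compounds shown alone.

Of the compounds shown here, three built on one shared core have been measured in an ADME assay on the whole organism for cytotoxicity, with Artemia salina as the target, with a stated time of 24 h; on this read-out higher numbers stand for an effect only at larger amounts of compound and lower numbers for an effect already at smaller amounts. Compound 1 `Cc1ccc(/C=C/C(=O)c2ccccc2NC(=O)NS(=O)(=O)c2ccc(C)cc2)cc1` gives 15.3 ug/mL. Compound 2 `COc1ccc(/C=C/C(=O)c2ccccc2NC(=O)NS(=O)(=O)c2ccc(C)cc2)c(OC)c1` gives 16 ug/mL, and compound 3 `Cc1ccc(S(=O)(=O)NC(=O)Nc2ccccc2C(=O)/C=C/c2ccc[nH]2)cc1` gives 32.1 ug/mL. Compound 2 stands second highest of the three numbers: the step of a 1.0-fold higher number from compound 1 to compound 2 (0.02 log units; within the scatter) lies within the scatter, and so does the step of a 2.0-fold higher number from compound 2 to compound 3 (0.30 log units; within the scatter).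

Compound 4 `Cc1ccc(S(=O)(=O)NC(=O)Nc2ccccc2C(=O)/C=C/c2cccnc2)cc1` has not yet been measured in this assay. Against compound 2 the change is pyridin-3-yl in place of 2,4-dimethoxyphenyl on a double-bonded chain carbon bound to a double-bonded chain carbon.

The measured steps that bear on this change are the two in which a 4-methylphenyl or a 2,4-dimethoxyphenyl group at the same place gave way to 1H-pyrrol-2-yl: the step of a 2.1-fold higher number from compound 1 to compound 3 (0.32 log units; beyond the scatter), a modest rise, and the step of a 2.0-fold higher number from compound 2 to compound 3 (0.30 log units; within the scatter), which stayed within the scatter. A similar small shift to a higher number in this assay, or no step beyond the scatter, is therefore expected here. For compound 4 the estimate is 22 ug/mL, within a range from 11 ug/mL to 45 ug/mL. This corresponds to an expected step of a 1.4-fold higher number from compound 2 to compound 4 (0.14 log units; within the scatter).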

Compound 4, concentration for half-maximal effect: 14.1 ug/mL
For compound 4 the middle estimate is 1.6-fold (0.19 log units) above the measured one; measured number inside the range.
By their numbers in this assay, from the lowest: compounds 4, 1, 2 and 3 (each within the scatter of the next, the first and the last beyond it).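

Pyridin-3-yl, a six-membered aromatic ring with one hetero atom, fits in at this place alongside the two carbon-only rings: in this assay both the step of a 1.1-fold lower number from compound 2 to compound 4 (0.05 log units; within the scatter) and the step of a 1.1-fold lower number from compound 1 to compound 4 (0.04 log units; within the scatter) stay within the scatter, although 2,4-dimethoxyphenyl has 10 heavy atoms and pyridin-3-yl has 6. The step of a 2.3-fold lower number from compound 3 to compound 4 (0.36 log units; beyond the scatter) lies beyond the scatter, so a hetero atom in the ring does not by itself go with the higher number: compound 3 carries 1H-pyrrol-2-yl and compound 4 carries pyridin-3-yl. Nothing available accounts for this gap between the two rings.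

Going by these compounds, it remains open whether pyridin-2-yl or pyridin-4-yl would behave like pyridin-3-yl here. On these data alone, it is also open where a group carrying an amine or a carboxylic acid at this place would fall.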